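A Fluorinated Phenyl Replaces Pyridin-4-yl on the Ring Nitrogen

A few compounds are considered here, and "the series" means these few. Any claim that something is new, unique, unknown or untested is made for them only; others in the source may bear on it.

Of the compounds shown here, three sharing one core have been measured so far. In a functional assay on CHO cells with adenosine receptor A1 (Homo sapiens) as the target, read by cAMP accumulation and immunoassay, with a stated time of 6 min, tested at 0.01 uM (a lower number here means a stronger effect, a higher number a weaker effect of the compound at the concentration tested), compound 1 `Nc1scc(CN2CCN(c3ccncc3)CC2)c1C(=O)c1ccc(Cl)cc1` gives -4%. Compound 2 `Nc1scc(CN2CCN(c3ccc(C(F)(F)F)cc3)CC2)c1C(=O)c1cccc(C(F)(F)F)c1` gives -12%, and compound 3 `Nc1scc(CN2CCN(c3c(F)cccc3F)CC2)c1C(=O)c1cccc(C(F)(F)F)c1` gives 2.1%. Compound 1 stands second highest of the three numbers; its gap to compound 3 and its gap to compound 2 both lie within the scatter, so no order among the three can be read from these values. Among the measured compounds shown here, the only measured step between neighbours, a number 14.1 percentage points higher from compound 2 to compound 3 (beyond the scatter), is modest and exchanges a group on the amine nitrogen in the ring. Compound 4 `Nc1scc(CN2CCN(c3c(F)cc(F)cc3F)CC2)c1C(=O)c1ccc(Cl)cc1` differs from compound 1 at that same place: 2,4,6-trifluorophenyl in place of pyridin-4-yl on an amine nitrogen in a ring. The step from compound 2 to compound 3 bears on this change only loosely, since the groups exchanged there are not the ones exchanged here, and it was modest in size; all three measured numbers sit close to zero. The author therefore expects no step beyond the scatter, a number 4 percentage points higher from compound 1 to compound 4 (within the scatter), and estimates for compound 4 a value of 0%, within a range from -15% to 15%.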

Compound 4, a percentage reported as activity, at one concentration (the size of the read-out at that concentration, not a potency): 4.2%
Compound 4: the middle estimate sits 4.2 percentage points below what was measured; the measured number falls inside the stated range.
By their numbers in this assay, from the lowest: compounds 2, 1, 3 and 4 (each within the scatter of the next, the first and the last beyond it).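

In this assay, the exchange at this position gives a number 8.2 percentage points higher from compound 1 to compound 4 (within the scatter). This is the first listed step on an amine nitrogen in a ring in which a six-membered aromatic ring with a hetero atom leaves and a ring of carbon only enters; the earlier step there, from compound 2 to compound 3, exchanged one substituted phenyl for another. On the core of compound 1, therefore, taking out the ring nitrogen and its hydrogen-bond acceptor and bringing in 2,4,6-trifluorophenyl leaves the read-out within the scatter, and nothing measured here offers an explanation for that outcome.

Each compound has a read-out at a single concentration. From the compounds shown here alone, the pair says nothing about potency, and whether pyridin-4-yl and 2,4,6-trifluorophenyl would still match at other concentrations remains open. Going by these compounds, it also remains open whether a group of another kind on this ring nitrogen, such as a phenyl bearing a carboxylic acid or an amine, or a longer chain ending in a phenyl, would bring a step beyond the scatter.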